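The source may hold more compounds than are shown below. What is called first, only, known or untested is meant among the compounds shown, and "the series" means these compounds.

Compound 1 `Nc1scc(CN2CCN(c3cccc(Cl)c3Cl)CC2)c1C(=O)c1ccc(Cl)cc1` gives -57% in a functional assay on CHO cells with adenosine receptor A1 (Homo sapiens) as the target, read by cAMP accumulation and immunoassay, with a stated time of 6 min, tested at 1 uM; a lower number here means a stronger effect, a higher number a weaker effect of the compound at the concentration tested.
Compound 2 `Nc1scc(CN2CCN(c3cccnc3)CC2)c1C(=O)c1ccc(Cl)cc1` gives -2.7% in this assay.
Compound 3 `Nc1scc(CN2CCN(c3ccccc3F)CC2)c1C(=O)c1ccc(Cl)cc1` gives -9.2% in this assay.

Among these three numbers compound 3 stands second highest. Its nearest neighbour is compound 2, separated by a number 6.5 percentage points lower from compound 2 to compound 3 (within the scatter), a gap inside the usual scatter, so the two cannot be told apart. The furthest is compound 1, reached by a number 47.8 percentage points higher from compound 1 to compound 3 (beyond the scatter), a large step.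

Compound 4 `Nc1scc(CN2CCN(c3ccc(Cl)c(Cl)c3)CC2)c1C(=O)c1ccc(Cl)cc1` is not yet measured. It differs from compound 3 in one place: 3,4-dichlorophenyl in place of 2-fluorophenyl on an amine nitrogen in a ring. Going by the values given here, the step that bears most directly on this change is the one from compound 1 to compound 3, a number 47.8 percentage points higher from compound 1 to compound 3 (beyond the scatter), where a dichlorophenyl was exchanged for the 2-fluorophenyl and the number rose sharply. The step of a number 54.3 percentage points higher from compound 1 to compound 2 (beyond the scatter) points the same way. Putting a dichlorophenyl back, although with its chlorines placed as 3,4-dichlorophenyl rather than 2,3-dichlorophenyl, is therefore expected to move the number back down, by a number 25.8 percentage points lower from compound 3 to compound 4 (beyond the scatter), though less surely than if compound 1 itself were being remade. Compound 4 is thus estimated at -35%, with a range from -65% to 0%.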

Compound 4, a percentage reported as activity, at one concentration (the size of the read-out at that concentration, not a potency): -60%
Compound 4: the middle estimate sits 25 percentage points above what was measured, and the stated range covers the measured number.
By their numbers in this assay, from the lowest: compounds 4 and 1 (each within the scatter of the next); then compounds 3 and 2 (each within the scatter of the next).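

Moving the chlorines from the 2,3-dichlorophenyl to the 3,4-dichlorophenyl arrangement leaves this assay unchanged within the scatter, a number 3 percentage points lower from compound 1 to compound 4 (within the scatter), so the large effect is not tied to a single chlorine pattern. Against the groups without chlorine, the second dichlorophenyl group gives steps as large as the first, a number 50.8 percentage points lower from compound 3 to compound 4 (beyond the scatter) and a number 57.3 percentage points lower from compound 2 to compound 4 (beyond the scatter), and across these four compounds, both dichlorophenyl groups give low numbers while 2-fluorophenyl and pyridin-3-yl give high numbers, with no compound going against this. Nothing available here explains this split.

Still open, on these data alone, is whether one chlorine is enough, as in 3-chlorophenyl or 4-chlorophenyl, since the step from 2-fluorophenyl changes both the halogen and how many there are. Whether other groups at these ring places, such as methyl or methoxy, would give similarly low numbers is also unsettled.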